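Stripping the Amide from Compound 3: What to Expect

A few compounds are considered here, and "the series" means these few. Any claim that something is new, unique, unknown or untested is made for them only; others in the source may bear on it.

Compound 1 `CCOC(=O)CCCCCOc1cccc(CN(C(=O)c2ccccc2)C(C)C)c1` is the simplest member of the set, an amide built on the shared core. In an ADME assay on BJ cells (Homo sapiens) for cytotoxicity, read by CellTiter-Glo and resazurin assay, with a stated time of 72 h (a lower number here means that less compound is needed, a higher number that more compound is needed for the effect), compound 1 gives only a limit, > 26000 nM. Compound 2 `CCOC(=O)CCCCCOc1cccc(CN(C(=O)c2ccc(-c3cccc(NC(C)=O)c3)cc2)C(C)C)c1` carries 3-acetamidophenyl in place of hydrogen on an aromatic carbon; in this assay compound 2 also gives only a limit, > 26000 nM. Compound 3 `CCOC(=O)CCCCCOc1cccc(CN(C(=O)c2ccc(Br)cc2)C(C)C)c1` carries bromo in place of hydrogen on an aromatic carbon, and in this assay compound 3 likewise returns only a limit, > 26000 nM. The steps among them, a step that the two limits leave unreadable from compound 1 to compound 2, a step that the two limits leave unreadable from compound 1 to compound 3 and a step that the two limits leave unreadable from compound 2 to compound 3, are of unreadable size because of the limit of > 26000 nM in this assay, at which 3 of the 3 values shown sit.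

Compound 4 `CCOC(=O)CCCCCOc1cccc(CNC(C)C)c1` differs from compound 3 by hydrogen in place of (4-bromophenyl)carbonyl on an amine nitrogen: the amide is removed and a secondary amine remains. Among the compounds with values here, none of the measured steps touches the amine nitrogen, so none bears directly on this change; they show only that changing the aryl end of the amide left every compound at the limit. Compound 4 is therefore expected to stay at or past the limit as well. The step that the limit leaves unreadable from compound 3 to compound 4 is expected to be small or, more likely, unreadable. The estimate for compound 4 is 40000 nM, with a range from 15000 nM to 150000 nM.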

Compound 4, half-maximal effective concentration: > 26000 nM
Compound 4 was reported as a limit (the forecaster's own chance of this, stated with the estimate: 80%); the middle value does not contradict the limit.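

Within the data shown here, compound 4 also returns only a limit in this assay, so no step linking it to compound 3 or compound 1 can be read, because all four compounds share one limit: the limit of > 26000 nM in this assay, at which 4 of the 4 values shown sit.

The compounds shown leave open at what concentration any of the four would reach the half-maximal effect, and whether removing the amide changes it.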